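Allyl guaiacol esters: ring swap on the carbonyl carbon

A few compounds are considered here, and "the series" means these few. Any claim that something is new, unique, unknown or untested is made for them only; others in the source may bear on it.

Going by the values given here, compound 2 `C=CCc1ccc(OC(=O)c2ccncc2)c(OC)c1` stands at the lower of the two numbers measured so far: in a physicochemical assay for lipophilicity (on this read-out higher numbers stand for higher lipophilicity and lower numbers for lower lipophilicity), compound 2 gives 0.86, while the only other measured member, compound 1 `C=CCc1ccc(OC(=O)c2cccc(F)c2)c(OC)c1`, gives 2.7 in this assay. Among the compounds with values here, the single measured step runs toward compound 2 and is large: a number 1.84 log units lower from compound 1 to compound 2 (beyond the scatter). Compound 3 `C=CCc1ccc(OC(=O)c2cccc(C)c2)c(OC)c1` differs from compound 2 by 3-methylphenyl in place of pyridin-4-yl on a carbonyl carbon. This change is of the same kind as the measured one, taken in reverse: a six-membered aromatic ring of carbon only returns to the carbonyl carbon in place of pyridin-4-yl. That earlier step, a number 1.84 log units lower from compound 1 to compound 2 (beyond the scatter), is the only one that bears on the present change, and it was large and downward. An upward step of comparable size is therefore expected for compound 3: a number 2.24 log units higher from compound 2 to compound 3 (beyond the scatter). For compound 3 the estimated value in this assay is 3.1, with a range from 2.7 to 3.5.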

Compound 3, partition coefficient: 2.87
Compound 3: the middle estimate sits 0.23 log units above what was measured, within the range that was stated.
By their numbers in this assay, from the lowest: compound 2; then compounds 1 and 3 (each within the scatter of the next).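

On the carbonyl carbon, a second ring of carbon only now stands clear of pyridin-4-yl in this assay: 3-methylphenyl in place of pyridin-4-yl gives a number 2.01 log units higher from compound 2 to compound 3 (beyond the scatter) and leaves compound 2 alone at the low end of the three compounds. Methyl in place of fluoro on an aromatic carbon gives a number 0.17 log units higher from compound 1 to compound 3 (within the scatter) and so does not separate these two groups on this read-out. Nothing measured here gives a reason for either step.

Open, going by these compounds, is how an amine, a carboxylic acid or a longer chain on the same ring would read in this assay against these three compounds. Also open, on these data alone, is whether a pyridin-4-yl ring carrying a methyl would stay with compound 2 or move towards compound 1 and compound 3.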